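This account rests on a few compounds, and the source may have more. Where it says the series, first, only, none or still open, it means among the compounds named here.

In a functional assay on HGC-27 cells (Homo sapiens) for cytotoxicity, read by MTT assay, with a stated time of 48 h (on this read-out lower numbers stand for stronger inhibition and higher numbers for weaker inhibition), both measured compounds of the series end at a limit of the assay. Compound 1 (`COc1ccc(/C=C/C(=O)/C=C/c2cc3ccccc3nc2Oc2ccccc2)c(OC)c1`) gives a limit and no number (> 10000 nM). Compound 2 (`COc1cc(OC)c(/C=C/C(=O)/C=C/c2cc3ccccc3nc2Oc2ccccc2)c(OC)c1`) likewise gives only a limit (> 10000 nM). Compound 2 therefore stands at the limit of > 10000 nM in this assay, at which 2 of the 2 values shown sit, and has no number to rank it. Compound 3 (`COc1cc(OC)c(/C=C/C(=O)/C=C/c2cc3ccccc3nc2Oc2ccccc2C(C)C)c(OC)c1`) changes the phenoxy group of compound 2 to 2-isopropylphenoxy: isopropyl in place of hydrogen on an aromatic carbon. Among the measured compounds shown here, the one measured step, a step that the two limits leave unreadable from compound 1 to compound 2, is a different change, methoxy in place of hydrogen on an aromatic carbon, and offers no size to carry over. For the measured compounds named here, no measured step supports a gain or a loss, so no clear move beyond the scatter is expected, and another limit is the likeliest report. The estimated step is a step that the limit leaves unreadable from compound 2 to compound 3. For compound 3 the expected value is 12000 nM (estimated range 3000 nM to 30000 nM).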

Compound 3, half-maximal inhibitory concentration: > 10000 nM
Compound 3 ended at the assay's limit (the forecaster's own chance of this, stated with the estimate: 65%); the middle value lies beyond the limit too.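

Compound 2 and compound 3 both end at a limit of the assay and give no number, so the step between them cannot be read. From the compounds shown here alone, whether isopropyl in place of hydrogen on an aromatic carbon changes the response in this assay stays open.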